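This account rests on a few compounds, and the source may have more. Where it says the series, first, only, none or still open, it means among the compounds named here.

Measured so far:
- compound 1, `CCOc1ccccc1-c1ccc(-c2nc3cnccc3c(N[C@H](CC)C(N)=O)c2C#N)cc1`: 3
- compound 2, `CC[C@@H](Nc1c(C#N)c(-c2ccc(-c3ccccc3NC)cc2)nc2cnccc12)C(N)=O`: 2.5
- compound 3, `CC[C@@H](Nc1c(C#N)c(-c2ccc(-c3ccccc3N(C)C)cc2)nc2cnccc12)C(N)=O`: 3.2

In a physicochemical assay for lipophilicity, read by HPLC, at pH 7.5 (a higher number here means a more lipophilic compound, a lower number a more polar compound), compound 3 stands at the top of the three numbers; compound 1 is nearest to it, a number 0.20 log units higher from compound 1 to compound 3 (within the scatter), which is within the scatter, while compound 2 is furthest, a number 0.70 log units higher from compound 2 to compound 3 (beyond the scatter), which is beyond the scatter. Going by the values given here, the step to compound 2 is the only one of the three steps that counts, and it is modest.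

Compound 4 is `CC[C@@H](Nc1c(C#N)c(-c2ccc(-c3cccc(C)c3)cc2)nc2cnccc12)C(N)=O`. It differs from compound 3 in one place: 3-methylphenyl in place of 2-(dimethylamino)phenyl on an aromatic carbon. The group that leaves carries an acceptor on its ring, the group that enters carries none and is smaller by two heavy atoms.

Among the compounds with values here, none of the measured steps exchanges the whole substituted ring, so no step bears directly on this change. The step of a number 0.20 log units higher from compound 1 to compound 3 (within the scatter) shows that exchanging one neutral group for another on that ring moved this assay only within the scatter; the step of a number 0.70 log units higher from compound 2 to compound 3 (beyond the scatter) shows that a single methyl on the nitrogen moved it modestly upward. A methyl on carbon in place of a dimethylamino is therefore expected to move this assay little, and if anything upward, so compound 4 is expected to give 3.4, between 2.9 and 3.9, a step of a number 0.20 log units higher from compound 3 to compound 4 (within the scatter).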

Compound 4, distribution coefficient: 3
The estimate for compound 4 lay 0.40 log units above the measured number; low and high end bracket the measured number.
By their numbers in this assay, from the lowest: compound 2; then compounds 1, 4 and 3 (each within the scatter of the next).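

In this assay the exchange of the substituted ring gives a number 0.20 log units lower from compound 3 to compound 4 (within the scatter) and, starting from the ethoxy compound, no change at the digits printed from compound 1 to compound 4 (within the scatter), so at this position, para to a large group, 3-methylphenyl cannot be told apart from either 2-(dimethylamino)phenyl or 2-ethoxyphenyl, even though it carries no acceptor and has a different place for its substituent. Going by these compounds alone, only the step from 2-(methylamino)phenyl stands clear, with a number 0.50 log units higher from compound 2 to compound 4 (beyond the scatter), which leaves compound 2 as the one compound of the four separated from the rest, while compounds 1, 3 and 4 sit together in this assay whether the ring bears a carbon, nitrogen or oxygen substituent. Nothing at hand explains why the groups fall this way.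

The compounds shown leave open whether this insensitivity extends to a ring bearing a carboxylic acid or a primary amine, where a charged group would replace the neutral ones seen so far. They also leave open whether 2-methylphenyl would match 3-methylphenyl, since the methyl group and the ring position change together in every step to compound 4.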